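The compounds below may be only part of what the source reports. "The series", "measured", "known", "first", "only" and "open" are said of these compounds alone.

Compound 1 `COc1ccc(C(=O)NCc2ccc(CNS(=O)(=O)c3ccccc3)cc2)cc1` gives 1000 nM in an assay on MDA-MB-231 cells for binding affinity to C-X-C chemokine receptor type 4 (Homo sapiens), read by immunofluorescence and microscopy, with stated times of 10 min and 30 min; on this read-out lower numbers stand for an effect already at smaller amounts and higher numbers for an effect only at larger amounts of compound.
Compound 2 `COc1ccccc1C(=O)NCc1ccc(CNS(=O)(=O)c2ccccc2)cc1` gives 1 nM.
Compound 3 `O=C(NCc1ccc(CNS(=O)(=O)c2ccccc2)cc1)c1ccccc1` gives 1 nM.

Compound 3 stands level with compound 2 at the digits recorded, and the two together hold the lowest numbers of the three. Compound 1 is the outlier: the step of a 1000-fold lower number from compound 1 to compound 3 (3.00 log units; beyond the scatter) and the step of a 1000-fold lower number from compound 1 to compound 2 (3.00 log units; beyond the scatter) show that a methoxy group para to the carbonyl carries a very large penalty, while the step of no change at the digits printed from compound 2 to compound 3 (within the scatter) shows that a methoxy group at the other position changes nothing.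

Compound 4 `Cc1ccc(C(=O)NCc2ccc(CNS(=O)(=O)c3ccccc3)cc2)cc1` carries the change (methyl in place of hydrogen on an aromatic carbon). The methyl enters at the same place on the ring where the methoxy of compound 1 sat, para to a large group. Among the compounds with values here, two measured steps bear on this: the pair of steps ending at compound 1 make substitution at that position look costly, but they concern a methoxy, not a methyl, and no measured compound shows what a methyl does there. A moderate rise in the number is therefore expected for compound 4, well short of the size seen for compound 1, estimated as a 20-fold higher number from compound 3 to compound 4 (1.30 log units; beyond the scatter). Compound 4 is expected to give 20 nM, in the range 1 nM to 500 nM.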

Compound 4, effective concentration (reported as EC, without a stated level of effect): 100 nM
Compound 4: the middle estimate sits 5.0-fold (0.70 log units) below what was measured, and the stated range covers the measured number.
By their numbers in this assay, from the lowest: compounds 2 and 3 (each within the scatter of the next); then compound 4; then compound 1.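

Methyl in place of hydrogen, para to a large group, is enough to raise the number sharply (a 100-fold higher number from compound 3 to compound 4 (2.00 log units; beyond the scatter)), and the 4-methylphenyl group in place of 2-methoxyphenyl gives a step of the same size (a 100-fold higher number from compound 2 to compound 4 (2.00 log units; beyond the scatter)), so the penalty at this place is not confined to the methoxy. The penalty also depends on the group, since methyl in place of methoxy at this place recovers part of it (a 10-fold lower number from compound 1 to compound 4 (1.00 log units; beyond the scatter)). No measured evidence accounts for this cost or for the gap between the two groups.

From the compounds shown here alone, whether a fluorine, a hydroxyl or an amine at this place would carry a similar penalty remains open. So does whether a methyl at the ring position held by the methoxy of compound 2 would leave the number unchanged, as that methoxy does.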